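Swapping the ether oxygen for sulfur on a quinoxaline diamine

The compounds below may be only part of what the source reports. "The series", "measured", "known", "first", "only" and "open" are said of these compounds alone.

Measured compounds:
- compound 1, `Nc1cc(N)c2nc(-c3ccccc3)c(Oc3ccc(Cl)c(Cl)c3)nc2c1`: 5620 nM
- compound 2, `CCOC(=O)[C@H](CCC(=O)O)NC(=O)c1ccc(Oc2nc3cc(N)cc(N)c3nc2-c2ccccc2)cc1`: 40700 nM

Both compounds were tested in a functional assay on SK-MEL-2 cells (Homo sapiens) for inhibition, read by sulforhodamine B assay, with a stated time of 48 h; on this read-out lower numbers stand for stronger inhibition of growth and higher numbers for weaker inhibition of growth. Compound 1, with its 3,4-dichlorophenoxy group on the shared core, gives 5620 nM and stands as the lower of the two numbers. Compound 2, which carries a much larger ester-bearing side chain in place of the dichlorophenoxy group, gives 40700 nM in this assay, a higher number that lies beyond the usual scatter; so of the two, compound 1 shows the stronger growth inhibition.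

Compound 3, `Nc1cc(N)c2nc(-c3ccccc3)c(Sc3ccc(Cl)c(Cl)c3)nc2c1`, has not yet been measured. It differs from compound 1 in one place only: (3,4-dichlorophenyl)sulfanyl in place of 3,4-dichlorophenoxy on an aromatic carbon. The ring, its two chlorines and the single hydrogen-bond acceptor all stay; only the linking atom changes from oxygen to sulfur. No comparable exchange exists among the measured pairs, so there is no direct guide to the size of this step. For a change this small, the expectation is a step of no clear direction, likely within the scatter, giving a 1.1-fold lower number from compound 1 to compound 3 (0.05 log units; within the scatter) as the estimated shift. Compound 3 is therefore expected to give about 5000 nM in this assay, with a plausible range from 1500 nM to 16000 nM.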

Compound 3, concentration for 50% growth inhibition: 6170 nM
Compound 3: the middle estimate sits 1.2-fold (0.09 log units) below what was measured; measured number inside the range.
By their numbers in this assay, from the lowest: compounds 1 and 3 (each within the scatter of the next); then compound 2.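

The exchange of 3,4-dichlorophenoxy for (3,4-dichlorophenyl)sulfanyl on this aromatic carbon gives, in this assay, a 1.1-fold higher number from compound 1 to compound 3 (0.04 log units; within the scatter) and so leaves compound 1 and compound 3 within the scatter of each other. Among the compounds shown here, the earlier compounds offered no case in which only the linking atom differed, so this pair is the first to isolate that single atom, and at this position on the shared core the read-out does not separate oxygen from sulfur. Nothing measured here explains why the two linked compounds read alike. Going by these compounds, the result covers only these two linking atoms with this one dichlorinated ring, so it remains open whether an amine or a methylene as the link, or a sulfone in place of the sulfanyl group, would also stay within the scatter of compound 1. On these data alone, it also remains open whether the same exchange would read alike if the 3,4-dichlorophenyl ring gave way to an unsubstituted phenyl ring or to a ring bearing a carboxylic acid.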